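The source may report more compounds than this note shows. Statements on the series, on what has been measured and on what is new or still open speak of the compounds shown alone.

Measured compounds:
compound 1 `CC(C)c1cccc(NC(=O)N[C@@H](C)c2ccccc2)c1` — 86%
compound 2 `C[C@H](NC(=O)Nc1cccc(C(F)(F)F)c1)c1ccccc1` — 92%

In an ADME assay on the whole organism with Oryza sativa as the target, tested at 10 uM (on this read-out higher numbers stand for a weaker effect at the one concentration tested and lower numbers for a stronger effect), compound 2 gives 92%, the highest of the two numbers, with compound 1 nearest; the step of a number 6 percentage points higher from compound 1 to compound 2 (within the scatter) lies within the scatter. Compound 3 `CCOC(=O)c1cccc(NC(=O)N[C@@H](C)c2ccccc2)c1` differs from compound 2 by ethoxycarbonyl in place of trifluoromethyl on an aromatic carbon. Going by the values given here, no measured step involves an ethoxycarbonyl group, so the only comparison to hand, a number 6 percentage points higher from compound 1 to compound 2 (within the scatter), shows that exchanging one group at this position left the read-out unchanged beyond the scatter. Compound 3 is therefore expected to behave much as compound 2, with a step of about a number 4 percentage points lower from compound 2 to compound 3 (within the scatter). The estimate for compound 3 is 88%, ranging from 74% to 99%.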

Compound 3, a percentage reported as activity, at one concentration (the size of the read-out at that concentration, not a potency): 96%
For compound 3 the middle estimate is 8 percentage points below the measured one, within the range that was stated.
By their numbers in this assay, from the lowest: compounds 1, 2 and 3 (each within the scatter of the next).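

In this assay, ethoxycarbonyl gives a number 4 percentage points higher from compound 2 to compound 3 (within the scatter) when it replaces trifluoromethyl and a number 10 percentage points higher from compound 1 to compound 3 (within the scatter) when it replaces isopropyl. This position therefore takes a third group, the first here with hydrogen-bond acceptors and a double bond outside aromatic rings, without the read-out moving beyond the scatter. No evidence is available to account for this result. Going by these compounds, whether an amine or a carboxylic acid on this aromatic carbon would shift the read-out beyond the scatter remains open. So does whether any group elsewhere on the shared core would.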